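Methoxy for methyl beside the ethynyl of compound 1

The compounds below may be only part of what the source reports. "The series", "measured", "known", "first", "only" and "open" are said of these compounds alone.

Compound 1 `C#Cc1cn([C@@H]2O[C@H](CO)[C@@H](O)[C@H]2O)c2ncnc(C)c12` is the anchor of this set. For the measured compounds named here, in a functional assay on CEM-DNR-bulk cells (Homo sapiens), read by MTT assay, with a stated time of 72 h (on this read-out lower numbers stand for stronger inhibition and higher numbers for weaker inhibition), compound 1 gives 160 nM, the lowest of the two numbers known. Compound 3 `Cc1ncnc2c1c(-c1ccsc1)cn2[C@@H]1O[C@H](CO)[C@@H](O)[C@H]1O` carries thiophen-3-yl in place of ethynyl on an aromatic carbon and gives 8560 nM, so that a 54-fold higher number from compound 1 to compound 3 (1.73 log units; beyond the scatter). Compound 2 `Cc1ncnc2c1c(-c1cc3ccccc3o1)cn2[C@@H]1O[C@H](CO)[C@@H](O)[C@H]1O` carries 1-benzofuran-2-yl in place of ethynyl on an aromatic carbon; compound 2 reaches only a limit of the assay, > 20000 nM (the limit of > 20000 nM in this assay, at which 1 of the 3 values shown sits). Between these two, an at least 2.3-fold lower number from compound 2 to compound 3 (0.36 log units; beyond the scatter).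

Compound 4 `C#Cc1cn([C@@H]2O[C@H](CO)[C@@H](O)[C@H]2O)c2ncnc(OC)c12` keeps the ethynyl group and differs from compound 1 only here: methoxy in place of methyl on an aromatic carbon

Going by the values given here, no measured step touches this position; every measured step varies the ethynyl carbon instead. The expected step is therefore small, a 2.5-fold higher number from compound 1 to compound 4 (0.40 log units; beyond the scatter), a slight loss if any. Compound 4 is estimated at 400 nM, between 100 nM and 2000 nM.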

Compound 4, half-maximal inhibitory concentration: 3490 nM
For compound 4 the middle estimate is 8.7-fold (0.94 log units) below the measured one; the whole stated range lies below it.
By their numbers in this assay, from the lowest: compound 1; then compound 4; then compound 3. At a limit, above all of these: compound 2.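

With the ethynyl group kept, this position proves sensitive on its own: methoxy in place of methyl gives a 22-fold higher number from compound 1 to compound 4 (1.34 log units; beyond the scatter). In this assay, for the compounds shown here, the earlier compounds showed sensitivity only at the ethynyl carbon, so the methyl is now a second place where a single change costs much. Nothing shown gives a reason for this step.

Open, as far as these compounds go, is whether the oxygen or the larger group governs the loss. An ethyl, an amine or a chlorine at this position would help separate the two.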